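The source may hold more compounds than are shown below. What is called first, only, known or untested is meant among the compounds shown, and "the series" means these compounds.

Compound 3, `COc1cc(Oc2cccc(Nc3ccccc3)c2)cc(OC)c1CCO`, gives 12100 nM in a functional assay on HCT-15 cells (Homo sapiens) for inhibition, read by MTT assay, with a stated time of 72 h (on this read-out lower numbers stand for stronger inhibition and higher numbers for weaker inhibition), the highest of the three numbers recorded: compound 2, `CCN1CCN(Cc2c(OC)cc(Oc3cccc(Nc4ccccc4)c3)cc2OC)CC1`, gives 5090 nM, and compound 1, `COc1ccc(CCCNCc2c(OC)cc(Oc3cccc(Nc4ccccc4)c3)cc2OC)cc1`, gives 730 nM. The step of a 17-fold higher number from compound 1 to compound 3 (1.22 log units; beyond the scatter) is the largest among the measured pairs, and a 2.4-fold higher number from compound 2 to compound 3 (0.38 log units; beyond the scatter) points the same way, both showing that a hydroxymethyl at this position is the weakest of the three substituents tried. Compound 4, `COc1cc(Oc2cccc(Nc3ccccc3)c2)cc(OC)c1CNCc1ccc(Br)cc1`, carries the change ((4-bromobenzyl)amino in place of hydroxymethyl on a saturated chain carbon bound to an aromatic carbon). The nearest analogue is compound 1, whose substituent is likewise a secondary amine on a saturated chain carbon bound to an aromatic carbon, and the step of a 17-fold higher number from compound 1 to compound 3 (1.22 log units; beyond the scatter) therefore bears most directly on the present one, with a 7.0-fold higher number from compound 1 to compound 2 (0.84 log units; beyond the scatter) suggesting that the size of the gain depends on the amine chosen. The expectation is thus a markedly lower number for compound 4, an 8.1-fold lower number from compound 3 to compound 4 (0.91 log units; beyond the scatter), though probably not quite back to compound 1. Compound 4 is estimated at 1500 nM, with a range from 500 nM to 5000 nM.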

Compound 4, half-maximal inhibitory concentration: 5410 nM
The estimate for compound 4 lay 3.6-fold (0.56 log units) below the measured number, outside the stated range (above it).
By their numbers in this assay, from the lowest: compound 1; then compounds 2 and 4 (each within the scatter of the next); then compound 3.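

In this assay, a secondary amine in place of hydroxymethyl does not by itself reach the level of compound 1: (4-bromobenzyl)amino brings only a 2.2-fold lower number from compound 3 to compound 4 (0.35 log units; beyond the scatter), while changing what the amine nitrogen carries gives a 7.4-fold higher number from compound 1 to compound 4 (0.87 log units; beyond the scatter), so the group on that nitrogen counts, not the nitrogen alone. With a 1.1-fold higher number from compound 2 to compound 4 (0.03 log units; within the scatter), the (4-bromobenzyl)amino group shows no separation from 4-ethylpiperazin-1-yl, so a secondary amine as such is no advantage here, and only compound 1 stands apart. No data given here explain these differences.

The step from 4-bromophenyl to 2-(4-methoxyphenyl)ethyl changes the chain length and the ring substituent together, so the compounds shown cannot say which of the two matters. A (4-methoxybenzyl)amino or a (3-(4-bromophenyl)propyl)amino group would separate them.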